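The source may hold more compounds than are shown below. What is called first, only, known or untested is meant among the compounds shown, and "the series" means these compounds.

Measured compounds: compound 1 `COc1cccc(OS(=O)(=O)c2ccc(N3CCN(C)C3=O)cc2)c1` gives 1600 nM in a functional assay on M21 cells (Homo sapiens) for antiproliferative activity, read by sulforhodamine B assay, with a stated time of 48 h; on this read-out lower numbers stand for stronger inhibition and higher numbers for weaker inhibition. Compound 2 `CN1CCN(c2ccc(S(=O)(=O)Oc3cccc(Cl)c3)cc2)C1=O` gives 1600 nM. Compound 3 `CN1CCN(c2ccc(S(=O)(=O)Oc3ccc(F)cc3)cc2)C1=O` gives > 100000 nM, which is a limit of the assay and not a number.

Compound 3 therefore stands at the weak end of what was measured, reached through an at least 62-fold higher number from compound 1 to compound 3 (1.79 log units; beyond the scatter) and an at least 62-fold higher number from compound 2 to compound 3 (1.79 log units; beyond the scatter). Compound 4 `CCCN1CCN(c2ccc(S(=O)(=O)Oc3ccc(F)cc3)cc2)C1=O` differs from compound 3 by ethyl in place of hydrogen on a saturated chain carbon bound to an amide-type nitrogen in a ring. Among the compounds with values here, no measured step touches this part of the molecule: no change at the digits printed from compound 1 to compound 2 (within the scatter) and the two large steps all change the ring on the oxygen, so they give no guide to the size or direction of this change. Because compound 3 sits at the limit of > 100000 nM in this assay, at which 1 of the 3 values shown sits, compound 4 is expected to remain near that limit, with a number no higher from compound 3 to compound 4 (the limit leaves the size open). Compound 4 is estimated at 100000 nM, within 20000 nM to 300000 nM.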

Compound 4, half-maximal inhibitory concentration: 14000 nM
Estimate against measurement, compound 4: 7.1-fold (0.85 log units) above, outside the stated range (below it).
By their numbers in this assay, from the lowest: compounds 1 and 2 (each within the scatter of the next); then compound 4. At a limit, above all of these: compound 3.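

Ethyl in place of hydrogen on a saturated chain carbon bound to an amide-type nitrogen in a ring gives an at least 7.1-fold lower number from compound 3 to compound 4 (0.85 log units; beyond the scatter) in this assay, so this position, which no earlier step touched, does affect the read-out. The value of compound 3, > 100000 nM, is a limit of the assay and not a number. The step's true size stays open because it starts from that limit: the limit of > 100000 nM in this assay, at which 1 of the 4 values shown sits.

On these data alone, whether a butyl chain or a chain carrying an amine would lower the number further remains open. So does whether the methyl to propyl change acts the same way with 3-methoxyphenyl or 3-chlorophenyl on the oxygen.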